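Series notes: chain-carbon aryl swap in compound 4

The source may hold more compounds than are shown below. What is called first, only, known or untested is meant among the compounds shown, and "the series" means these compounds.

Compound 1 (`CC(C)Cc1ccc2c(NCCCNCc3ccco3)ccnc2c1`) gives 9.47 in a physicochemical assay for acid dissociation, level with compound 2 (`COc1cccc(CNCCCNc2ccnc3cc(CC(C)C)ccc23)c1O`) at 9.47 and compound 3 (`COc1ccc(F)cc1CNCCCNc1ccnc2cc(CC(C)C)ccc12`) at 9.47. The steps of no change at the digits printed from compound 1 to compound 2 (within the scatter), no change at the digits printed from compound 1 to compound 3 (within the scatter) and no change at the digits printed from compound 2 to compound 3 (within the scatter) all stayed within the scatter. Compound 4 (`N#Cc1ccc(Cc2ccc3c(NCCCNCc4ccco4)ccnc3c2)cc1`) differs from compound 1 by 4-cyanophenyl in place of isopropyl on a saturated chain carbon bound to an aromatic carbon, placed on a saturated chain carbon bound to an aromatic carbon. Among the compounds with values here, no measured step touches that position; the three steps seen only exchanged the aryl group on the chain carbon bound to the amine nitrogen, each without change. With nothing pointing to a shift beyond the scatter, the step of a number 0.07 log units lower from compound 1 to compound 4 (within the scatter) is expected to be small. Compound 4 is therefore estimated at 9.4, between 9.1 and 9.7.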

Compound 4, acid dissociation constant: 9.47
Compound 4: middle estimate off by 0.07 log units, on the low side; the measured number falls inside the stated range.
By their numbers in this assay, from the lowest: compounds 1, 2, 3 and 4 (each within the scatter of the next).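

In this assay, 4-cyanophenyl in place of isopropyl on a saturated chain carbon bound to an aromatic carbon gives no change at the digits printed from compound 1 to compound 4 (within the scatter). This is the only reading at this position among the compounds shown, since the earlier steps all exchanged the aryl group on the chain carbon bound to the amine nitrogen. Nothing available explains why the read-out holds here.

One step sets no pattern for this position. As far as these compounds go, whether an amine or a carboxylic acid in place of isopropyl would give a step beyond the scatter remains open.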